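Swapping the methoxyphenyl for a pyridyl in a cytotoxic series

This account rests on a few compounds, and the source may have more. Where it says the series, first, only, none or still open, it means among the compounds named here.

Measured so far:
compound 1 `Cc1ccc(CNC(=O)CC2c3ccccc3N=C(N3CCN(CCN(C)C)CC3)N2c2ccc(-c3ccccc3)cc2)cc1` — 2330 nM
compound 2 `COc1ccc(CNC(=O)CC2c3ccccc3N=C(N3CCN(CCN(C)C)CC3)N2c2ccc(-c3ccccc3)cc2)cc1` — 2470 nM

In a functional assay on SK-OV-3 cells (Homo sapiens) for cytotoxicity, read by MTT assay, with a stated time of 48 h (a higher number here means a weaker inhibitor, a lower number a stronger inhibitor), compound 2 sits alongside compound 1: the step of a 1.1-fold higher number from compound 1 to compound 2 (0.03 log units; within the scatter) is within the scatter, so the two cannot be told apart. Compound 3 `CN(C)CCN1CCN(C2=Nc3ccccc3C(CC(=O)NCc3ccncc3)N2c2ccc(-c3ccccc3)cc2)CC1` carries pyridin-4-yl in place of 4-methoxyphenyl on a saturated chain carbon bound to an amide-type nitrogen. Among the measured compounds shown here, only that one step touches this position, and it barely moved the number, so the change to compound 3 is expected to stay within the scatter in this assay, with no clear direction. Compound 3 is therefore estimated at 2500 nM, in a range from 1200 nM to 5500 nM, which is expected as a step of a 1.0-fold higher number from compound 2 to compound 3 (0.01 log units; within the scatter).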

Compound 3, half-maximal inhibitory concentration: 11700 nM
Estimate against measurement, compound 3: 4.7-fold (0.67 log units) below; the measured number lies above the stated range.
By their numbers in this assay, from the lowest: compounds 1 and 2 (each within the scatter of the next); then compound 3.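

In this assay this position proves sensitive to the change: pyridin-4-yl in place of the carbon-only aromatic ring gives a 4.7-fold higher number from compound 2 to compound 3 (0.68 log units; beyond the scatter) and a 5.0-fold higher number from compound 1 to compound 3 (0.70 log units; beyond the scatter), whereas swapping methyl for methoxy gave only a 1.1-fold higher number from compound 1 to compound 2 (0.03 log units; within the scatter). Among these three compounds, then, changing the ring itself moves the number, while changing the small group on it does not. Nothing available explains this loss of activity.

From the compounds shown here alone, whether pyridin-3-yl or a plain phenyl on the same chain carbon would behave like pyridin-4-yl stays open.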